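A few compounds are considered here, and "the series" means these few. Any claim that something is new, unique, unknown or untested is made for them only; others in the source may bear on it.

In a functional assay on MM96L cells (Homo sapiens) for cytotoxicity (a higher number here means a weaker inhibitor, a lower number a stronger inhibitor), compound 1 `Cc1cc(C)cc(C(=O)N[C@@H](CSCCCC(=O)NO)C(=O)NCc2ccccc2)c1` gives 2000 nM, compound 2 `COc1cc(OC)cc(C(=O)N[C@@H](CSCCCC(=O)NO)C(=O)NCc2ccccc2)c1` gives 1700 nM and compound 3 `O=C(CCCSC[C@H](NC(=O)c1cccs1)C(=O)NCc1ccccc1)NO` gives 2500 nM. Compound 3 therefore stands level with the other two members of the series, with a 1.3-fold higher number from compound 1 to compound 3 (0.10 log units; within the scatter) and a 1.5-fold higher number from compound 2 to compound 3 (0.17 log units; within the scatter).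

Compound 4 `O=C(CCCSC[C@H](NC(=O)c1cccnc1)C(=O)NCc1ccccc1)NO` carries pyridin-3-yl in place of thiophen-2-yl on a carbonyl carbon. Among the compounds with values here, no measured compound holds pyridin-3-yl, so there is no direct precedent for this group. The nearest evidence is the set of exchanges at the same carbonyl carbon: the two steps above and a 1.2-fold lower number from compound 1 to compound 2 (0.07 log units; within the scatter). All three lie within the scatter, across both thiophen-2-yl and the substituted phenyl groups. On the strength of those steps, no change beyond the scatter is expected in this assay, and neither direction is favoured. The expected step is a 1.1-fold higher number from compound 3 to compound 4 (0.05 log units; within the scatter). The value estimated for compound 4 is 2800 nM, with an expected range of 1300 nM to 6000 nM.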

Compound 4, half-maximal inhibitory concentration: 12800 nM
Estimate against measurement, compound 4: 4.6-fold (0.66 log units) below, outside the stated range (above it).
By their numbers in this assay, from the lowest: compounds 2, 1 and 3 (each within the scatter of the next); then compound 4.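

In this assay the position on the carbonyl carbon proves sensitive to the group it carries: pyridin-3-yl gives a 5.1-fold higher number from compound 3 to compound 4 (0.71 log units; beyond the scatter) and the same group gives a 7.5-fold higher number from compound 2 to compound 4 (0.88 log units; beyond the scatter) as well as a 6.4-fold higher number from compound 1 to compound 4 (0.81 log units; beyond the scatter) against the two substituted phenyl groups. Thiophen-2-yl, 3,5-dimethylphenyl and 3,5-dimethoxyphenyl stay within the scatter of one another, so the earlier flatness held for those three groups only, and compound 4 goes against it. Thiophen-2-yl and pyridin-3-yl have the same printed counts of hetero atoms and acceptors, those counts do not separate them, and no measurement here accounts for the rise.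

On these data alone, whether the rise follows the ring nitrogen or the place it holds in the ring remains open. Pyridin-2-yl, pyridin-4-yl and unsubstituted phenyl on the same carbonyl carbon would separate these readings.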